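Phenyl in place of hydroxymethyl at the end of the chain

This account rests on a few compounds, and the source may have more. Where it says the series, first, only, none or still open, it means among the compounds named here.

Compound 1, `CSc1nc(NCCCCCO)c2ccccc2n1`, gives in a functional assay on HT-29 cells (Homo sapiens) for cytotoxicity, read by MTT assay, with a stated time of 72 h (a lower number here means a stronger inhibitor of growth, a higher number a weaker inhibitor of growth), only a limit, > 100000 nM.
Compound 2, `C[Se]c1nc(N)c2cccnc2n1`, gives in this assay 44100 nM.
Compound 3, `CSc1nc(Nc2ccccc2)c2ccccc2n1`, gives in this assay 65800 nM.

Compound 1 therefore has no number of its own, only the limit (the limit of > 100000 nM in this assay, at which 1 of the 3 values shown sits). Compound 4, `CSc1nc(NCCCCc2ccccc2)c2ccccc2n1`, is made from it by the change (phenyl in place of hydroxymethyl on a saturated chain carbon, four bonds along the chain from a nitrogen on an aromatic ring). For the measured compounds named here, the one measured step that bears on this, where a phenyl also replaces a hydroxyl-bearing chain, is an at least 1.5-fold lower number from compound 1 to compound 3 (0.18 log units; that floor lies within the scatter), a lowering that rests on a limit. A lower number than compound 1 is expected for compound 4, with the step estimated as an at least 2.0-fold lower number from compound 1 to compound 4 (0.30 log units; that floor lies within the scatter). Compound 4 is thus estimated at 50000 nM, within 15000 nM to 150000 nM.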

Compound 4, concentration for 50% growth inhibition: > 100000 nM
Compound 4: only a limit was reported; the forecaster's own chance of this, stated with the estimate: 35%; at least 2.0-fold (0.30 log units) between middle value and limit.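

Compound 1 and compound 4 both stand only as limits, so no step between them can be read: the limit of > 100000 nM in this assay, at which 2 of the 4 values shown sit.

The compounds shown leave open whether phenyl in place of hydroxymethyl at this chain end changes growth inhibition at all.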